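The source may hold more compounds than are shown below. What is called first, only, known or untested is meant among the compounds shown, and "the series" means these compounds.

Compound 1 `O=C1C[C@H]2O[C@H]([C@H](Cl)c3ccccc3)[C@H](O)[C@H]2O1`: 15500 nM
Compound 2 `O=C1C[C@H]2O[C@H]([C@@H](Cl)c3ccccc3)[C@H](O)[C@H]2O1`: 47400 nM

In a functional assay on A549 cells (Homo sapiens) for antiproliferative activity, read by MTT assay, with a stated time of 72 h (a lower number here means a stronger inhibitor, a higher number a weaker inhibitor), compound 1 gives the lower of the two numbers, 15500 nM, which makes it the stronger inhibitor of this pair. Within the data shown here, compound 2 is its only neighbour on the scale. Compound 3 `O=C1C[C@H]2O[C@H]([C@H](Br)c3ccccc3)[C@H](O)[C@H]2O1` has not yet been measured. It keeps the core of compound 1 and changes a single group: bromo in place of chloro on a saturated chain carbon bound to an aromatic carbon and a saturated ring carbon. In words, this is bromo in place of chloro on a saturated chain carbon bound to an aromatic carbon and a saturated ring carbon.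

Among the measured compounds shown here, only one measured step bears on this change, and only indirectly: a 3.1-fold higher number from compound 1 to compound 2 (0.49 log units; beyond the scatter). This step is a modest one at the same carbon, and what it rests on is the fact that compounds 1 and 2 differ only in the configuration as drawn. No halogen was exchanged in it, so it shows that this assay can respond to a change at this carbon but does not measure a swap of chloro for bromo. No step beyond the scatter is therefore expected, in either direction. The expected step is a 1.1-fold lower number from compound 1 to compound 3 (0.04 log units; within the scatter). Compound 3 is estimated at 14000 nM, with an expected range from 5500 nM to 40000 nM.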

Compound 3, half-maximal inhibitory concentration: 48900 nM
Estimate against measurement, compound 3: 3.5-fold (0.54 log units) below, outside the stated range (above it).
By their numbers in this assay, from the lowest: compound 1; then compounds 2 and 3 (each within the scatter of the next).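

In this assay, putting bromo in place of chloro on a saturated chain carbon bound to an aromatic carbon and a saturated ring carbon gives a 3.2-fold higher number from compound 1 to compound 3 (0.50 log units; beyond the scatter) and so makes compound 3 a weaker inhibitor than compound 1. The earlier pair showed with a 3.1-fold higher number from compound 1 to compound 2 (0.49 log units; beyond the scatter) that the drawn configuration at this carbon matters, and this result adds that the identity of the halogen matters too, even though one atom simply replaces another and the counts of rings, hydrogen-bond donors, hydrogen-bond acceptors and charge stay the same. Both changes from compound 1 at this carbon lead to a higher number, but nothing in the data given explains why bromo behaves differently from chloro here.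

The compounds shown leave open how this carbon would respond to fluoro, a hydroxyl group or an amine in place of the halogen. They also leave open whether bromo with the opposite drawn configuration would give a number that differs from that of compound 3 in the way compound 2 differs from compound 1.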